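The source may report more compounds than this note shows. Statements on the series, on what has been measured and on what is new or still open speak of the compounds shown alone.

Of the compounds shown here, two have been measured in a functional assay on MIA PaCa-2 cells (Homo sapiens) for cytotoxicity, read by luminescence, with a stated time of 72 h, in the presence of a further agent that is not named here (on this read-out lower numbers stand for stronger inhibition and higher numbers for weaker inhibition), so far. Compound 1, with structure `CNc1c(F)ccc2c(C=NNC(=S)N(C)C)nccc12`, gives 38.4 nM in this assay. Compound 2, with structure `CN(C)C(=S)NN=Cc1nccc2ccccc12`, gives 73.7 nM in this assay. Of these two numbers compound 2 has the higher one, but its gap to compound 1 lies within the scatter of repeated measurements, so the two compounds cannot be told apart on this evidence.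

Compound 3, with structure `CN(C)C(=S)NN=Cc1nccc2cc(F)ccc12`, has not yet been measured in this assay. It differs from compound 2 by a single change: fluoro in place of hydrogen on an aromatic carbon. Within the data shown here, no step between measured compounds that matches this change is available, so the expectation for compound 3 rests only on the nearness of the two measured numbers. Compound 3 is expected to give about 60 nM in this assay, with a range from 25 nM to 150 nM. This estimate means a step of a 1.2-fold lower number from compound 2 to compound 3 (0.09 log units; within the scatter), which is not expected to go beyond the scatter.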

Compound 3, half-maximal inhibitory concentration: 21.6 nM
The estimate for compound 3 lay 2.8-fold (0.44 log units) above the measured number; measured number outside the range, below it.
By their numbers in this assay, from the lowest: compounds 3, 1 and 2 (each within the scatter of the next, the first and the last beyond it).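

In this assay, fluoro in place of hydrogen on this aromatic carbon, meta to a fused ring and para to a fused ring, gives a 3.4-fold lower number from compound 2 to compound 3 (0.53 log units; beyond the scatter), so this single atom change moves the number beyond the scatter, which the gap between the two earlier compounds did not do. With fluoro in place, hydrogen in place of methylamino gives a 1.8-fold lower number from compound 1 to compound 3 (0.25 log units; within the scatter), within the scatter, so on this evidence the methylamino group is not needed to keep the number low. Nothing measured here bears on why the fluoro step has this size.

The compounds shown leave open whether chloro, methoxy or an amine on the same carbon would match fluoro. They also leave open what methylamino does on the shared core without fluoro.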